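The source may report more compounds than this note shows. Statements on the series, on what has been measured and on what is new or still open speak of the compounds shown alone.

Compound 2 `CCOC(=O)Nc1ccc(S(=O)(=O)N2C[C@H](c3ccccc3)NC2=O)cc1C` gives 70 nM in a functional assay on NCI-H460 cells (Homo sapiens) for cytotoxicity, read by MTT assay; a higher number here means a weaker inhibitor, a lower number a stronger inhibitor.
Compound 3 `CCOC(=O)Nc1ccc(S(=O)(=O)N2C[C@H](c3ccccc3)NC2=O)c(C)c1C` gives 300 nM in this assay.
Compound 1 `CCc1cc(S(=O)(=O)N2C[C@H](c3ccccc3)NC2=O)ccc1NC(=O)c1ccc([N+](=O)[O-])cc1` gives 800 nM in this assay.

Compound 2 has the lowest number of the three; compound 3 stands nearest to it and compound 1 furthest. Compound 4 `CCOC(=O)Nc1ccc(S(=O)(=O)N2C[C@H](c3ccccc3)NC2=O)cc1CC` differs from compound 2 by methyl in place of hydrogen on a saturated chain carbon bound to an aromatic carbon. Within the data shown here, the only measured step that bears on it, a 4.3-fold higher number from compound 2 to compound 3 (0.63 log units; beyond the scatter), added a methyl to an aromatic carbon of the shared core, whereas the present change extends the methyl already there, reading methyl to ethyl one bond further out. Among the measured compounds shown here, no measured pair isolates that exact change, so only a small loss is expected in this assay, estimated as a 1.7-fold higher number from compound 2 to compound 4 (0.23 log units; within the scatter). Compound 4 is therefore expected to give 120 nM, within 50 nM to 300 nM.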

Compound 4, half-maximal inhibitory concentration: 70 nM
Compound 4: middle estimate off by 1.7-fold (0.23 log units), on the high side, within the range that was stated.
By their numbers in this assay, from the lowest: compounds 2 and 4 (each within the scatter of the next); then compound 3; then compound 1.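

Reading methyl to ethyl at this saturated chain carbon bound to an aromatic carbon gives no change at the digits printed from compound 2 to compound 4 (within the scatter) in this assay, so this position tolerates the extra carbon. Compound 4 also gives a second end of the molecule a single-place comparison: ethoxy in place of 4-nitrophenyl on a carbonyl carbon gives an 11-fold lower number from compound 1 to compound 4 (1.06 log units; beyond the scatter) in this assay. Nothing available explains either step. As far as these compounds go, whether a longer chain, such as propyl, would hold the number at this position remains open. So does the effect of an amine there.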